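Working notes: the step from compound 2 to compound 4

This account rests on a few compounds, and the source may have more. Where it says the series, first, only, none or still open, it means among the compounds named here.

Measured so far in a functional assay on BaF3 cells (Mus musculus) for antiproliferative activity; a higher number here means that more compound is needed for the effect, a lower number that less compound is needed:
compound 1 `CCN1CCN(Cc2ccc(NC(=O)c3ccc(C)c(C#Cc4cccnc4)c3)cc2C(F)(F)F)CC1`: 1590 nM
compound 2 `CCN1CCN(Cc2ccc(NC(=O)c3ccc(C)c(C#Cc4ccc(NC(=O)C5CC5)nc4)c3)cc2C(F)(F)F)CC1`: 1800 nM
compound 3 `CCN1CCN(Cc2ccc(NC(=O)c3ccc(C)c(C#Cc4cnc5[nH]ccc5c4)c3)cc2C(F)(F)F)CC1`: 1000 nM

On these numbers compound 2 cannot be separated from the other two compounds, with a 1.1-fold higher number from compound 1 to compound 2 (0.05 log units; within the scatter) and a 1.8-fold lower number from compound 2 to compound 3 (0.26 log units; within the scatter) as its steps. Compound 4 `CCN1CCN(Cc2ccc(NC(=O)c3ccc(C)c(C#Cc4cnc5[nH]c(C)cc5c4)c3)cc2C(F)(F)F)CC1` carries a group of 10 heavy atoms (8 carbon, 2 nitrogen; one five-membered aromatic ring with 1 hetero atom, one six-membered aromatic ring with 1 hetero atom) in place of a group of 12 heavy atoms (9 carbon, 2 nitrogen, 1 oxygen; one three-membered non-aromatic ring of carbon only, one six-membered aromatic ring with 1 hetero atom), on a triple-bonded carbon. The nearest guide is a 1.8-fold lower number from compound 2 to compound 3 (0.26 log units; within the scatter), also a swap on the triple-bonded carbon, and a 1.6-fold lower number from compound 1 to compound 3 (0.20 log units; within the scatter) is of like size. Neither step leaves the scatter. In this assay the expected change is therefore small, a 1.8-fold lower number from compound 2 to compound 4 (0.26 log units; within the scatter), towards a lower number but with nothing expected beyond the scatter. Compound 4 is estimated at 1000 nM, with an expected range of 400 nM to 2500 nM.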

Compound 4, half-maximal effective concentration: 1000 nM
Compound 4: middle estimate and measured number agree at the digits printed, and the stated range covers the measured number.
By their numbers in this assay, from the lowest: compounds 3, 4, 1 and 2 (each within the scatter of the next).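

In this assay, methyl in place of hydrogen on an aromatic carbon gives no change at the digits printed from compound 3 to compound 4 (within the scatter), so this small addition to the group on the triple-bonded carbon cannot be told apart from hydrogen. The larger swaps, a 1.8-fold lower number from compound 2 to compound 4 (0.26 log units; within the scatter) and a 1.6-fold lower number from compound 1 to compound 4 (0.20 log units; within the scatter), also stay within the scatter, leaving all four groups at this place inseparable in this assay. No measurement is available that would explain this flat result.

Going by these compounds, whether an amine, a carboxylic acid or a longer chain in place of that methyl would move the number beyond the scatter remains open.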